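Amide aryl variation on the shared core: difluorophenyl next

A few compounds are considered here, and "the series" means these few. Any claim that something is new, unique, unknown or untested is made for them only; others in the source may bear on it.

Compound 1 `O=C(Nc1cccc(-c2oc3cc(-c4ccc(F)cc4)ccc3c(=O)c2O)c1)c1ccccc1F` gives 7570 nM in a functional assay on MCF7 cells (Homo sapiens) for antiproliferative activity, read by CCK-8 assay, with a stated time of 72 h; a lower number here means a stronger inhibitor, a higher number a weaker inhibitor. Among the compounds with values here, compound 2 `Cc1ccc(C(=O)Nc2cccc(-c3oc4cc(-c5ccc(F)cc5)ccc4c(=O)c3O)c2)cc1` gives 2400 nM, the lowest of the two numbers; the only step measured, a 3.2-fold lower number from compound 1 to compound 2 (0.50 log units; beyond the scatter), is the sole guide here. Compound 3 `O=C(Nc1cccc(-c2oc3cc(-c4ccc(F)cc4)ccc3c(=O)c2O)c1)c1ccc(F)cc1F` carries 2,4-difluorophenyl in place of 4-methylphenyl on a carbonyl carbon. Within the data shown here, since the one measured step runs from a fluorinated phenyl to the methylphenyl, returning to a fluorinated phenyl, now with two fluorines, is expected to move partly back toward compound 1, so a rise of a 1.9-fold higher number from compound 2 to compound 3 (0.27 log units; within the scatter) is expected in this assay. For compound 3 the estimate is 4500 nM, within 1800 nM to 11000 nM.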

Compound 3, half-maximal inhibitory concentration: 13500 nM
For compound 3 the middle estimate is 3.0-fold (0.48 log units) below the measured one, and the stated range ends below it.
By their numbers in this assay, from the lowest: compound 2; then compounds 1 and 3 (each within the scatter of the next).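

In this assay, within the data shown here, the 2,4-difluorophenyl group on the amide carbonyl is clearly less favourable than 4-methylphenyl, with a 5.6-fold higher number from compound 2 to compound 3 (0.75 log units; beyond the scatter) being the larger step seen at this position so far. Adding a second fluoro group gives a 1.8-fold higher number from compound 1 to compound 3 (0.25 log units; within the scatter) and so no readable change, which leaves compound 2 alone at the low end of the three. Nothing available accounts for the gap between the methyl and fluoro compounds.

As far as these compounds go, whether the lower number of compound 2 depends on the methyl group or only on the absence of fluoro remains open. So does the effect of a methoxy group or an amine on this phenyl ring.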